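The source may hold more compounds than are shown below. What is called first, only, known or untested is meant among the compounds shown, and "the series" means these compounds.

In a physicochemical assay for lipophilicity, read by HPLC, in phosphate buffer, measured as octanol-water partition, with a stated time of 1 h, at pH 7.4 (a lower number here means a more polar compound, a higher number a more lipophilic compound), compound 1 (`C[C@@]1(c2cc(NC(=O)c3ncc(C#N)cc3Cl)ccc2F)C=C(CF)OC(N)=N1`) gives 2.5 and compound 2 (`C[C@@]1(c2cc(NC(=O)c3ncc(OCF)nc3N)ccc2F)C=C(CF)OC(N)=N1`) gives 3.1 as the higher of the two numbers. Among the measured compounds shown here, the only measured step is a number 0.60 log units higher from compound 1 to compound 2 (beyond the scatter) and it came with 3-amino-5-(fluoromethoxy)pyrazin-2-yl in place of 3-chloro-5-cyanopyridin-2-yl on a carbonyl carbon. Compound 3 (`COc1cc(C#N)cnc1C(=O)Nc1ccc(F)c([C@]2(C)C=C(CF)OC(N)=N2)c1`) departs from compound 2 on that same carbonyl carbon: 5-cyano-3-methoxypyridin-2-yl in place of 3-amino-5-(fluoromethoxy)pyrazin-2-yl on a carbonyl carbon is the whole change. The entering 5-cyano-3-methoxypyridin-2-yl shares its 5-cyano and pyridin-2-yl with the group of compound 1 at 2.5 so the measured step, read in reverse, bears on this one, and a fall of similar modest size is expected in this assay on these grounds. The expected change is a number 0.80 log units lower from compound 2 to compound 3 (beyond the scatter) and would lie beyond the scatter. For compound 3 the estimate is 2.3 with an expected range from 1.9 to 2.7 in this measurement.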

Compound 3, distribution coefficient: 1.9
Beside the measured number, compound 3's estimate is 0.40 log units above it, and the stated range covers the measured number.
By their numbers in this assay, from the lowest: compound 3; then compound 1; then compound 2.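

Placing 5-cyano-3-methoxypyridin-2-yl on the carbonyl carbon gave a number 1.20 log units lower from compound 2 to compound 3 (beyond the scatter) in this assay, so this position can move the number downward as well as upward, and compound 3 now has the lowest value of the three. The comparison of compound 1 with compound 3 is narrower than the earlier step, since the whole group is not exchanged: methoxy in place of chloro on an aromatic carbon gave a number 0.60 log units lower from compound 1 to compound 3 (beyond the scatter) with the 5-cyano and pyridin-2-yl parts kept. A single substituent within the group is thus enough to produce a shift beyond the scatter.

From the compounds shown here alone, whether an amine or an ethoxy group on that aromatic carbon would give a similar number remains open. Nothing available here accounts for either shift.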